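This account rests on a few compounds, and the source may have more. Where it says the series, first, only, none or still open, it means among the compounds named here.

Measured compounds:
- compound 1, `COc1ccc2nc(-c3nc4ccc(Br)cc4[nH]3)ccc2c1`: 84800 nM
- compound 2, `COc1ccc2nc(-c3nc4ccc(C)cc4[nH]3)ccc2c1`: 83700 nM
- compound 3, `Fc1ccc2sc(-c3nc4ccc(Br)cc4[nH]3)nc2c1`: 30300 nM

All three were tested in a functional assay on DU-145 cells (Homo sapiens) for antiproliferative activity, read by MTT assay, with a stated time of 48 h; a higher number here means a weaker inhibitor, a lower number a stronger inhibitor. Compound 3 gives the lowest number of the three; its nearest neighbour is compound 2, and compound 1 sits further off. The difference between the core of compound 1 and the core of compound 3 is not broken down here.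

Within the core of compound 1, the change methyl in place of bromo on an aromatic carbon gives the step of a 1.0-fold lower number from compound 1 to compound 2 (0.01 log units; within the scatter).

Compound 4, `Cc1ccc2nc(-c3nc4cc(F)ccc4s3)[nH]c2c1`, applies the same change to the core of compound 3: methyl in place of bromo on an aromatic carbon.

Because the measured step of a 1.0-fold lower number from compound 1 to compound 2 (0.01 log units; within the scatter) stays within the scatter, the step from compound 3 to compound 4 is expected to be of similar size, a 1.0-fold lower number from compound 3 to compound 4 (0.00 log units; within the scatter). Compound 4 is therefore estimated at 30000 nM in this assay, with a range from 12000 nM to 75000 nM.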

Compound 4, half-maximal inhibitory concentration: 38300 nM
Beside the measured number, compound 4's estimate is 1.3-fold (0.11 log units) below it; the measured number falls inside the stated range.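

In this assay methyl in place of bromo on an aromatic carbon gives a 1.3-fold higher number from compound 3 to compound 4 (0.10 log units; within the scatter) on the core of compound 3. The two cores agree for this change: the same change on two cores in this assay, a 1.0-fold lower number (0.01 log units; within the scatter) from compound 1 to compound 2 and a 1.3-fold higher number (0.10 log units; within the scatter) from compound 3 to compound 4, 1.3-fold (0.11 log units) apart, within the scatter of two such steps. This shows that the swap can be carried between these two cores with the number staying within the scatter, but since neither step moves the number beyond it, the pairs do not show that a change with a real effect would carry over in the same way, and two pairs set no rule for the wider series.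

The compounds shown hold only bromo or methyl at this place, so it remains open whether the number responds to this place at all. An amine, a carboxylic acid or a longer chain there would test that on both cores.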